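A few compounds are considered here, and "the series" means these few. Any claim that something is new, unique, unknown or untested is made for them only; others in the source may bear on it.

Measured compounds and values:
compound 1 `N#CC1=C(N)Oc2c(c3nc4ccccc4nc3c3ccccc23)C12C(=O)N(Cc1cnnn1-c1ccc(F)cc1)c1ccccc12` gives > 50000 nM — a limit of the assay, not a number.
compound 2 `N#CC1=C(N)Oc2c(c3nc4ccccc4nc3c3ccccc23)C12C(=O)N(Cc1cnnn1-c1ccc(Cl)cc1)c1ccccc12` gives > 50000 nM — a limit of the assay, not a number.
compound 3 `N#CC1=C(N)Oc2c(c3nc4ccccc4nc3c3ccccc23)C12C(=O)N(Cc1cnnn1-c1ccccc1Br)c1ccccc12` gives > 50000 nM — a limit of the assay, not a number.

In a functional assay on A549 cells (Homo sapiens) for antiproliferative activity, read by MTT assay, with a stated time of 48 h (a higher number here means a weaker inhibitor, a lower number a stronger inhibitor), compound 1 therefore has no measured number at all, only a limit. The same holds for compound 2 in this assay. Compound 3 likewise reaches only a limit in this assay. All three sit at the limit of > 50000 nM in this assay, at which 3 of the 3 values shown sit.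

The unmeasured compound 4 `CCOc1ccccc1-n1nncc1CN1C(=O)C2(C(C#N)=C(N)Oc3c2c2nc4ccccc4nc2c2ccccc32)c2ccccc21` differs from compound 1 in one place: 2-ethoxyphenyl in place of 4-fluorophenyl on an aromatic nitrogen. The measured steps that bear on this change are those between the aryl groups on the same aromatic nitrogen: a step that the two limits leave unreadable from compound 1 to compound 2, a step that the two limits leave unreadable from compound 1 to compound 3 and a step that the two limits leave unreadable from compound 2 to compound 3. None of them can be read, since every one of the three values is a limit, so no size or direction of step is available for a change of the aryl group at this position.

Given that compound 1 stands only at a limit, the step that the limit leaves unreadable from compound 1 to compound 4 is expected to be unreadable as well, with compound 4 most likely again at the limit. Compound 4 is estimated at 60000 nM in this assay, in a range from 20000 nM to 200000 nM.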

Compound 4, half-maximal inhibitory concentration: > 50000 nM
Compound 4: only a limit was reported (the forecaster's own chance of this, stated with the estimate: 80%); the middle value is on the limit's open side.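

In this assay compound 4 gives > 50000 nM, a limit of the assay and not a number. Its steps from compound 1, compound 2 and compound 3 therefore cannot be read. The compounds shown leave open whether changing the aryl group on this aromatic nitrogen alters activity at all, and all four rest at one value: the limit of > 50000 nM in this assay, at which 4 of the 4 values shown sit.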